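The source may report more compounds than this note shows. Statements on the series, on what has been measured and on what is new or still open speak of the compounds shown alone.

Compound 1 `Cn1c(=O)c(S(=O)(=O)c2ccc(C(=O)O)cc2)cc2cnc(Nc3ccc4[nH]ccc4c3)nc21` belongs to a small set of three analogues built on a shared core and tested in a functional assay on K562 cells (Homo sapiens) for inhibition, read by trypan blue exclusion, with a stated time of 72 h; a higher number here means a weaker inhibitor, a lower number a stronger inhibitor. In this assay compound 1 gives 5000 nM. Compound 2 `CN1CCN(c2ccc(Nc3ncc4cc(S(=O)(=O)c5ccc(F)cc5F)c(=O)n(C)c4n3)cc2)CC1` gives 5000 nM in this assay, a number level with that of compound 1 at the digits recorded, so the two cannot be told apart. Compound 3 `Cc1ccc(S(=O)(=O)c2cc3cnc(Nc4cnc5[nH]ccc5c4)nc3n(C)c2=O)cc1` gives 15000 nM in this assay, a higher number than compound 1 by a gap beyond the usual scatter. Compound 1 and compound 2 therefore sit together at the lower end of the three numbers, with compound 3 standing apart from them.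

Compound 4 `Cn1c(=O)c(S(=O)(=O)Nc2ccc(F)cc2F)cc2cnc(Nc3ccc4[nH]ccc4c3)nc21` has not yet been measured. It differs from compound 1 in a single place: (2,4-difluorophenyl)amino in place of 4-carboxyphenyl on a sulfonyl sulfur. Within the data shown here, no pair of measured compounds differs by this change alone, so there is no measured step to lean on. Compound 2 carries a 2,4-difluorophenyl group on its sulfonyl sulfur, though with a different amine, and compound 2 gives 5000 nM. On that basis compound 4 is expected to land close to compound 1, with the step of a 1.3-fold lower number from compound 1 to compound 4 (0.10 log units; within the scatter) expected to stay within or only slightly beyond the scatter. For compound 4 the estimate is 4000 nM, with a range from 1500 nM to 12000 nM.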

Compound 4, half-maximal inhibitory concentration: 5000 nM
Estimate against measurement, compound 4: 1.3-fold (0.10 log units) below, within the range that was stated.
By their numbers in this assay, from the lowest: compounds 1, 2 and 4 (each within the scatter of the next); then compound 3.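

In this assay, among these compounds, placing (2,4-difluorophenyl)amino on the sulfonyl sulfur instead of 4-carboxyphenyl gives no change at the digits printed from compound 1 to compound 4 (within the scatter) and is the only measured step at this place, which the earlier compounds could not supply. It shows that this exchange, in which the two oxygen atoms of the carboxyphenyl group leave and a nitrogen and two fluorine atoms enter, while a six-membered aromatic ring of carbon only and the heavy-atom count stay the same, leaves the read-out on the core of compound 1 unmoved within the scatter. Nothing measured here accounts for that outcome.

Because this single step shows no movement, the compounds shown leave open whether any group on the sulfonyl sulfur can shift the number in either direction, for instance a morpholine, a plain methyl or a longer alkyl chain. They also leave open whether a (2,4-difluorophenyl)amino group carrying a carboxylic acid on its ring, or a bare phenyl ring in the same place, would stay level with compound 1 in this assay on this core.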